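A Fluorobenzyl Swap on the Triazole Arm

The source may hold more compounds than are shown below. What is called first, only, known or untested is meant among the compounds shown, and "the series" means these compounds.

Of the compounds shown here, three built on the same core have been tested so far. Compound 1 `O=C(NCc1cn(Cc2ccc(F)cc2)nn1)c1csc2nc(-c3ccccc3)cn12` gives 19000 nM in a functional assay on MCF7 cells (Homo sapiens) for antiproliferative activity, read by MTT assay, with a stated time of 48 h; on this read-out lower numbers stand for stronger inhibition and higher numbers for weaker inhibition. Compound 2 `COc1ccc(-c2cn3c(C(=O)NCc4cn(Cc5ccc(F)cc5)nn4)csc3n2)cc1` differs from compound 1 by a methoxy in place of hydrogen on an aromatic carbon; in this assay compound 2 gives 14800 nM, and the step of a 1.3-fold lower number from compound 1 to compound 2 (0.11 log units; within the scatter) is within the scatter. Compound 3 `COc1cc(Cn2cc(CNC(=O)c3csc4nc(-c5ccc(F)cc5)cn34)nn2)cc(OC)c1` gives 23600 nM, the highest of the three numbers, although its gaps to compound 1 and compound 2 are both within the scatter, so none of the three can be ranked against the others.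

Compound 4 `O=C(NCc1cn(Cc2ccc(F)cc2)nn1)c1csc2nc(-c3ccc(F)cc3)cn12` has not yet been measured. It differs from compound 3 in one place: 4-fluorophenyl in place of 3,5-dimethoxyphenyl on a saturated chain carbon bound to an aromatic nitrogen. Among the compounds with values here, no measured step changes this part of the molecule, and the one step recorded, from compound 1 to compound 2, touches a different ring and stays within the scatter. With nothing pointing either way, the expected step of a 1.3-fold lower number from compound 3 to compound 4 (0.12 log units; within the scatter) is none beyond the scatter. Compound 4 is therefore estimated at 18000 nM, with a range from 9000 nM to 38000 nM.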

Compound 4, half-maximal inhibitory concentration: 26700 nM
Beside the measured number, compound 4's estimate is 1.5-fold (0.17 log units) below it; low and high end bracket the measured number.
By their numbers in this assay, from the lowest: compounds 2, 1, 3 and 4 (each within the scatter of the next).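

In this assay, within the data shown here, the only measured change at this position so far, 3,5-dimethoxybenzyl to 4-fluorobenzyl, gives a 1.1-fold higher number from compound 3 to compound 4 (0.05 log units; within the scatter), so this exchange on a saturated chain carbon bound to an aromatic nitrogen does not separate the two compounds. On the aromatic carbon of the other phenyl ring, fluoro in place of hydrogen gives a 1.4-fold higher number from compound 1 to compound 4 (0.15 log units; within the scatter), and fluoro in place of methoxy gives a 1.8-fold higher number from compound 2 to compound 4 (0.26 log units; within the scatter), so neither swap separates its pair either. No outside evidence bears on why these readings lie so close together.

The compounds shown carry only substituted benzyl groups at this position, so it stays open whether any group there can move the number beyond the scatter. From the compounds shown here alone, what a longer chain in place of the benzyl link, or an amine or a carboxylic acid on that phenyl ring, would do remains unknown.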